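Removing a Methoxy Group from an Inactive Lignan-like Diol

The source may hold more compounds than are shown below. What is called first, only, known or untested is meant among the compounds shown, and "the series" means these compounds.

The study rests on two measured compounds. In a functional assay (Rattus norvegicus) for inhibition, with a stated time of 15 min, at 37 degrees C (on this read-out lower numbers stand for stronger inhibition and higher numbers for weaker inhibition), compound 1 `COc1cc([C@H](O)[C@@H](CO)Oc2c(OC)cc(CCCO)cc2OC)ccc1OC(CO)CO` gives 1620 nM. Compound 2 `COc1cc([C@@H](O)[C@@H](CO)Oc2c(OC)cc(CCCO)cc2OC)cc(OC)c1OC(CO)CO` reaches only the limit of this assay, recorded as > 50000 nM, so for compound 2 no number is known, only that it sits at the limit of > 50000 nM in this assay, at which 1 of the 2 values shown sits, together with none of the other values shown.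

Compound 3 `COc1cc([C@@H](O)[C@@H](CO)Oc2c(OC)cc(CCCO)cc2OC)ccc1OC(CO)CO` has not yet been measured in this assay. It departs from compound 2 by a single change, (hydrogen in place of methoxy on an aromatic carbon). Among the compounds with values here, no measured step between two compounds is available here, so the size of the expected change cannot be read from a precedent. Because compound 2 stands at the limit of > 50000 nM in this assay, at which 1 of the 2 values shown sits, any number that this assay reports for compound 3 would by itself mean stronger inhibition than the limit shows for compound 2. The account therefore expects the step of an at least 4.1-fold lower number from compound 2 to compound 3 (0.61 log units; beyond the scatter) to run toward stronger inhibition. Compound 3 is estimated at 12000 nM, within a range from 2500 nM to 50000 nM.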

Compound 3, half-maximal inhibitory concentration: > 50000 nM
Compound 3: no number, only a limit (the forecaster's own chance of this, stated with the estimate: 35%); at least 4.1-fold (0.61 log units) between middle value and limit.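

Compound 3 gives > 50000 nM in this assay, which is a limit of the assay and not a number. Hydrogen in place of methoxy on this aromatic carbon, ortho to the 2-hydroxy-1-(hydroxymethyl)ethoxy group, therefore yields no readable step, and the change cannot be sized here, as both ends of the pair rest on a limit: the limit of > 50000 nM in this assay, at which 2 of the 3 values shown sit. What the result adds lies in the comparison with compound 1, which was not available before: there is an at least 30-fold higher number from compound 1 to compound 3 (1.48 log units; beyond the scatter), a large step that goes with a single stereocentre at a saturated chain carbon, drawn S in compound 1 and R in compound 3, and with nothing else in the structure: the fact that compounds 1 and 3 differ only in the configuration as drawn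

The compounds shown leave open what the methoxy group does at this aromatic carbon when that stereocentre is drawn S, as no pair with that configuration differs in this one place. They also leave open whether an amine or a carboxylic acid on this aromatic carbon, where compound 1 carries hydrogen, would move the value of compound 1 in this assay.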